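An Amino Group Enters the Shared Core

The source may hold more compounds than are shown below. What is called first, only, known or untested is meant among the compounds shown, and "the series" means these compounds.

Measured so far in a functional assay on NCI-H23 cells (Homo sapiens) for cytotoxicity, read by sulforhodamine B assay, with a stated time of 48 h; a higher number here means that more compound is tolerated, a lower number that less compound is tolerated:
compound 1 `ClCc1ccccc1Cn1cnc2c(Cl)nc(Cl)nc21` gives 6310 nM;
compound 2 `ClCc1ccccc1Cn1cnc2c(Cl)ncnc21` gives 9330 nM;
compound 3 `ClCc1cccc(Cn2cnc3nc(Cl)nc(Cl)c32)c1` gives 5370 nM.

Compound 2 stands at the highest of these three numbers, yet its gaps to compound 1 and to compound 3 both lie within the scatter, so the three compounds sit together rather than in an order. Going by the values given here, only one pair differs in a single place: the step of a 1.5-fold higher number from compound 1 to compound 2 (0.17 log units; within the scatter) puts hydrogen in place of chloro on an aromatic carbon and stays within the scatter.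

Compound 4 `Nc1nc(Cl)c2ncn(Cc3ccccc3CCl)c2n1` is the next compound, not yet measured. It differs from compound 2 by amino in place of hydrogen on an aromatic carbon. Among the compounds with values here, no measured step introduces an amino group onto the shared core, and the single known change on that core left the number within the scatter, so nothing in the data points to a shift of any size in either direction. For compound 4, no step beyond the scatter is therefore expected in this assay. Compound 4 is estimated at 9000 nM, with a range from 3000 nM to 27000 nM. For compound 4 this estimate means an expected step of a 1.0-fold lower number from compound 2 to compound 4 (0.02 log units; within the scatter).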

Compound 4, concentration lethal to 50% of the cells: 78900 nM
Compound 4: middle estimate off by 8.8-fold (0.94 log units), on the low side, outside the stated range (above it).
By their numbers in this assay, from the lowest: compounds 3, 1 and 2 (each within the scatter of the next); then compound 4.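

In this assay, amino in place of hydrogen on this aromatic carbon between two ring nitrogen atoms gives an 8.5-fold higher number from compound 2 to compound 4 (0.93 log units; beyond the scatter) and so produces the first step beyond the scatter among these compounds. Amino in place of chloro on the same carbon gives a 13-fold higher number from compound 1 to compound 4 (1.10 log units; beyond the scatter) as the larger of the two new steps. Hydrogen and chloro on this carbon remain within the scatter of each other, as a 1.5-fold higher number from compound 1 to compound 2 (0.17 log units; within the scatter) shows, so the amino group is the first substituent here to separate from the others on this carbon.

As far as these compounds go, whether a methylamino group or a hydroxyl group on this carbon would give a step of similar size remains open, as does whether the amino step would carry over to the core of compound 3. Why amino has this effect also stays unanswered, for nothing available bears on the result.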